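Adding a second fluoro to the weakest-looking compound

The source may report more compounds than this note shows. Statements on the series, on what has been measured and on what is new or still open speak of the compounds shown alone.

Compound 2, `Oc1nc2nonc2nc1Nc1ccccc1F`, is one of three compounds tested in an assay on mitochondria from L6 cells (Rattus norvegicus) for activation, with a stated time of 90 min; a lower number here means that less compound is needed, a higher number that more compound is needed for the effect. In this assay compound 2 gives 12500 nM, the highest number of the three. Its closest neighbour is compound 3, `Oc1nc2nonc2nc1Nc1ccccc1C(F)(F)F`, which gives 10600 nM; the step of a 1.2-fold lower number from compound 2 to compound 3 (0.07 log units; within the scatter) lies within the scatter, so these two cannot be told apart. Far away stands compound 1, `Fc1cccc(Nc2nc3nonc3nc2Nc2ccccc2F)c1`, which gives 190 nM; the step of a 66-fold higher number from compound 1 to compound 2 (1.82 log units; beyond the scatter) shows how much the number rises when the (3-fluorophenyl)amino group is exchanged for hydroxy.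

Compound 4, `Oc1nc2nonc2nc1Nc1cccc(F)c1F`, differs from compound 2 in one place: fluoro in place of hydrogen on an aromatic carbon. The new fluoro sits on an aromatic carbon of a six-membered aromatic ring of carbon only, ortho to a fluoro group. Going by the values given here, the only measured step on this same ring is the one from compound 2 to compound 3, and it was within the scatter. Among the compounds with values here, no measured step shows what a second fluoro on this ring does, so the expectation rests on that single small step.

The step of a 1.1-fold lower number from compound 2 to compound 4 (0.06 log units; within the scatter) is therefore expected to stay within the scatter. Compound 4 is estimated at 11000 nM, with a range from 4000 nM to 30000 nM.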

Compound 4, half-maximal effective concentration: 9700 nM
Compound 4: the middle estimate sits 1.1-fold (0.05 log units) above what was measured; measured number inside the range.
By their numbers in this assay, from the lowest: compound 1; then compounds 4, 3 and 2 (each within the scatter of the next).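

In this assay, putting fluoro in place of hydrogen on this aromatic carbon, ortho to a fluoro group, gives a 1.3-fold lower number from compound 2 to compound 4 (0.11 log units; within the scatter), so the two compounds cannot be told apart. The earlier step on this ring, a 1.2-fold lower number from compound 2 to compound 3 (0.07 log units; within the scatter), exchanged the existing fluoro for trifluoromethyl, whereas this change fills a place that held only hydrogen, and adding this single heavy atom there also produces no readable difference. No measured property of these compounds bears on this result.

The compounds shown leave open whether this place would stay as insensitive to a larger group, such as methoxy, an amine or a carboxylic acid, since fluoro is the only group tested there. They also leave open whether the same added fluoro would make a readable difference in a compound that carries a (3-fluorophenyl)amino group in place of the hydroxy, as compound 1 does at 190 nM, because a change that is invisible with hydroxy present need not stay invisible with that group.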